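Methoxyphenyl in Place of Chlorophenyl at the Ceiling

A few compounds are considered here, and "the series" means these few. Any claim that something is new, unique, unknown or untested is made for them only; others in the source may bear on it.

Compound 3 `Cc1ccc(Nc2nc(C)c(C(=O)/C=C/c3ccccc3Cl)s2)cc1` stands at the edge of what a functional assay on BGC-823 cells (Homo sapiens) for cytotoxicity, read by MTT assay (a higher number here means a weaker inhibitor, a lower number a stronger inhibitor), can resolve: its value of > 25000 nM is a limit rather than a number. In this assay compound 1 `COc1cccc(/C=C/C(=O)c2sc(Nc3ccccc3)nc2C)c1` gives 14300 nM. Compound 2 `COc1cccc(/C=C/C(=O)c2sc(Nc3ccccc3C)nc2C)c1` reaches only the limit of > 25000 nM. Among the compounds with values here, the step of an at least 1.7-fold higher number from compound 1 to compound 2 (0.24 log units; that floor lies within the scatter) is the sole measured step, and its floor lies within the scatter. Compound 4 `COc1cccc(/C=C/C(=O)c2sc(Nc3ccc(C)cc3)nc2C)c1` arises from compound 3 by 3-methoxyphenyl in place of 2-chlorophenyl on a double-bonded chain carbon bound to a double-bonded chain carbon. Within the data shown here, no measured step covers this exchange directly; compound 1 and compound 2 carry the same 3-methoxyphenyl group that enters in compound 4, and the picture across all three is shaped by the limit of > 25000 nM in this assay, at which 2 of the 3 values shown sit, so little separation between them can be read. The expected step of an at least 1.2-fold lower number from compound 3 to compound 4 (0.09 log units; that floor lies within the scatter) is accordingly none beyond the scatter, with compound 4 expected to sit near the ceiling once more. Compound 4 is estimated to give about 20000 nM, within a range from 8000 nM to 50000 nM.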

Compound 4, half-maximal inhibitory concentration: > 25000 nM
Compound 4 gave a limit, no number (the forecaster's own chance of this, stated with the estimate: 50%); at least 1.2-fold (0.09 log units) between middle value and limit.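

In this assay compound 4 gives > 25000 nM, a limit of the assay and not a number. The steps to compound 4 from compound 3 and from compound 2 cannot be read, so neither 3-methoxyphenyl in place of 2-chlorophenyl nor 4-methylphenyl in place of 2-methylphenyl has a measurable size here: the limit of > 25000 nM in this assay, at which 3 of the 4 values shown sit. Within the data shown here, the one readable step, an at least 1.7-fold higher number from compound 1 to compound 4 (0.24 log units; that floor lies within the scatter), adds a second methyl placement to the earlier one, yet it shows no change beyond the scatter.

As far as these compounds go, whether 2-chlorophenyl and 3-methoxyphenyl differ at all on a double-bonded chain carbon bound to a double-bonded chain carbon remains open, as does any difference between the two methylphenyl groups on the nitrogen. Also open, from the compounds shown here alone, is whether an aminophenyl or a carboxyphenyl group at the first of these places would bring the series back to a readable number.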